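The compounds below may be only part of what the source reports. "The series", "measured", "known", "first", "only" and "open" are said of these compounds alone.

In a functional assay on HL-60 cells (Homo sapiens) for inhibition (on this read-out lower numbers stand for stronger inhibition and higher numbers for weaker inhibition), compound 3 `OC[C@H]1OC(n2cnc3c(-c4ccc(F)cc4)ncnc32)[C@H](O)[C@@H]1O` gives 6300 nM, which lies within the scatter of compound 1 `OC[C@H]1OC(n2cnc3c(-c4ccccn4)ncnc32)[C@H](O)[C@@H]1O` at 5600 nM and compound 2 `Cc1csc(-c2ncnc3c2ncn3C2O[C@H](CO)[C@@H](O)[C@H]2O)c1` at 5600 nM. Compound 4 `OC[C@H]1OC(n2cnc3c(-c4nccs4)ncnc32)[C@H](O)[C@@H]1O` differs from compound 3 in one group, with 1,3-thiazol-2-yl in place of 4-fluorophenyl on an aromatic carbon. Three measured swaps of one aromatic group for another on the shared core bear on this change: a 1.1-fold higher number from compound 1 to compound 3 (0.05 log units; within the scatter), a 1.1-fold higher number from compound 2 to compound 3 (0.05 log units; within the scatter) and no change at the digits printed from compound 1 to compound 2 (within the scatter). None moved the number beyond the scatter, so no clear step is expected in this assay, though a new group could still surprise. The estimate means a 1.3-fold lower number from compound 3 to compound 4 (0.10 log units; within the scatter). Compound 4 is expected to give about 5000 nM, within a range of 1500 nM to 15000 nM.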

Compound 4, half-maximal inhibitory concentration: 6300 nM
Estimate against measurement, compound 4: 1.3-fold (0.10 log units) below, within the range that was stated.
By their numbers in this assay, from the lowest: compounds 1, 2, 3 and 4 (each within the scatter of the next).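

The 1,3-thiazol-2-yl group gives no change at the digits printed from compound 3 to compound 4 (within the scatter) and a 1.1-fold higher number from compound 2 to compound 4 (0.05 log units; within the scatter) and a 1.1-fold higher number from compound 1 to compound 4 (0.05 log units; within the scatter). This adds a fourth aromatic group at this position, and the first ring holding both sulfur and nitrogen, yet all four compounds remain within the scatter of one another in this assay. No measurement available here accounts for this flat result. As far as these compounds go, what stays open is whether a group that is not an aromatic ring, such as an amine, a carboxylic acid or a longer alkyl chain, would move the number at this position.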